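Swapping Methyl for Trifluoromethyl on a Shared Core

This account rests on a few compounds, and the source may have more. Where it says the series, first, only, none or still open, it means among the compounds named here.

Compound 1 `CN(C(=O)NC(=O)c1ccc(Cl)cc1Cl)c1nc(C(F)(F)F)c(C(=O)N/N=C/c2ccc(C(F)(F)F)cc2)s1` in a functional assay on HepG2 cells (Homo sapiens) for inhibition, read by MTT assay, with a stated time of 72 h (a higher number here means a weaker inhibitor, a lower number a stronger inhibitor), gives 12.4 ug/mL.
Compound 2 `CNc1nc(C)c(C(=O)N/N=C/c2cccc(C(F)(F)F)c2)s1` in this assay gives only a limit of the assay, > 100 ug/mL.
Compound 3 `CNc1nc(C(F)(F)F)c(C(=O)N/N=C/c2cccc(C(F)(F)F)c2)s1` in this assay gives only a limit of the assay, > 100 ug/mL.

Compound 3 and compound 2 differ in a single place, (methyl in place of trifluoromethyl on an aromatic carbon). Because both of their values are limits, the step that the two limits leave unreadable from compound 3 to compound 2, and this rests on (the limit of > 100 ug/mL in this assay, at which 2 of the 3 values shown sit). The same kind of change leads from compound 1 to compound 4 `Cc1nc(N(C)C(=O)NC(=O)c2ccc(Cl)cc2Cl)sc1C(=O)N/N=C/c1ccc(C(F)(F)F)cc1`, namely (methyl in place of trifluoromethyl on an aromatic carbon). The surroundings of the place are not identical: in compound 3 the place is two ring bonds from the ring atom that bears a methylamino group, whereas in compound 1 it is two ring bonds from the ring atom that bears a large group. How the core of compound 1 differs from the core of compound 3 is not broken down here. Among the three measured compounds, compound 1 is the only one with a number in this assay; the other two values are limits.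

The measured pair gives no readable size for this change, so the expectation for compound 4 rests on compound 1 at 12.4 ug/mL together with the unreadable a step that the two limits leave unreadable from compound 3 to compound 2. The step expected from this change is a 1.6-fold higher number from compound 1 to compound 4 (0.21 log units; within the scatter). For compound 4 the estimated value is 20 ug/mL, expected to fall between 6 ug/mL and 80 ug/mL.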

Compound 4, half-maximal inhibitory concentration: > 100 ug/mL
Compound 4: no number, only a limit (the forecaster's own chance of this, stated with the estimate: 20%); middle value at least 5.0-fold (0.69 log units) from the limit.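

On the core of compound 1, methyl in place of trifluoromethyl on the aromatic carbon gives, in this assay, an at least 8.0-fold higher number from compound 1 to compound 4 (0.90 log units; beyond the scatter), so on this core the change clearly comes with weaker inhibition. Compound 4 gives > 100 ug/mL, which is a limit of the assay and not a number, so this step has a known minimum but no known full size. The same change on the core of compound 3 cannot be read, so the series does not show whether the change has a similar size on both cores, and the result on one core cannot be said to carry over to the other, because the values on that core and the value of compound 4 all stop at the same ceiling: the limit of > 100 ug/mL in this assay, at which 3 of the 4 values shown sit.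

The compounds shown leave open how other groups on this aromatic carbon, such as an ethyl group, a chlorine atom or a plain hydrogen, would compare with the trifluoromethyl of compound 1 and the methyl of compound 4. They also leave open how large the full step is, and whether any group at this place could give a readable number on the core of compound 3.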